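This account rests on a few compounds, and the source may have more. Where it says the series, first, only, none or still open, it means among the compounds named here.

Among the measured compounds shown here, in a functional assay on L1210 cells (Mus musculus), with a stated time of 2 days (on this read-out lower numbers stand for stronger inhibition and higher numbers for weaker inhibition), compound 2 `C=C1C=CCO[C@@H]1n1ccc(N)nc1=O` gives 1390000 nM and stands highest of the two numbers known so far. Compound 1 `C=C1C=CCO[C@@H]1n1cc(C)c(O)nc1=O` gives 486000 nM on this read-out. The gap between compound 2 and compound 1 lies beyond the scatter. Compound 3 `C=C1C=CCO[C@@H]1n1ccc(O)nc1=O` differs from compound 2 by hydroxy in place of amino on an aromatic carbon with hydroxy in place of amino on an aromatic carbon. For the measured compounds named here, compound 1 also carries hydroxy and gives 486000 nM as the only guide, although no measured pair shows this change alone. In this assay the expected step is a 2.3-fold lower number from compound 2 to compound 3 (0.36 log units; beyond the scatter) as a modest move toward a lower number. For compound 3 the estimated value is 600000 nM with an expected range from 200000 nM to 1800000 nM overall.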

Compound 3, half-maximal inhibitory concentration: 549000 nM
Estimate against measurement, compound 3: 1.1-fold (0.04 log units) above, and the stated range covers the measured number.
By their numbers in this assay, from the lowest: compounds 1 and 3 (each within the scatter of the next); then compound 2.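

In this assay, hydroxy in place of amino on this aromatic carbon gives a 2.5-fold lower number from compound 2 to compound 3 (0.40 log units; beyond the scatter) as a single change, which the earlier pair could not show. Hydrogen in place of methyl on an aromatic carbon gives a 1.1-fold higher number from compound 1 to compound 3 (0.05 log units; within the scatter) and so leaves the number within the scatter, which means the methyl of compound 1 has no readable effect on it here. Nothing available explains either step.

The compounds shown leave open whether methoxy or a longer chain at the hydroxy position would shift the number further, and whether the methyl would stay without readable effect alongside amino.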